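A Single Inverted Stereocentre on the Shared Core

This account rests on a few compounds, and the source may have more. Where it says the series, first, only, none or still open, it means among the compounds named here.

In an assay on Sf9 cells for inhibition of histone deacetylase 11 (Homo sapiens), read by fluorescence, tested at 0.5 uM (on this read-out higher numbers stand for more inhibition at the one concentration tested (going by the name of the read-out) and lower numbers for less inhibition), compound 3 (`O=C(NO)c1cccc(-c2cn([C@H]3C[C@@H](C(=O)O)N(CCCc4ccccc4)C3)nn2)c1`) sits at a limit, giving < 10%. Compound 1 (`O=C(NO)c1cccc(-c2cn([C@@H]3C[C@H](C(=O)O)N(CCCc4ccccc4)C3)nn2)c1`) likewise reaches only a limit in this assay at < 10%. Compound 2 (`O=C(NO)c1cccc(-c2cn([C@@H]3C[C@@H](CO)N(CCCc4ccccc4)C3)nn2)c1`) also gives the limit < 10% in this assay. Among the compounds with values here, the one measured step that concerns configuration, a step that the two limits leave unreadable from compound 1 to compound 3, cannot be read because of the limit of < 10% in this assay, at which 3 of the 3 values shown sit, both of its ends being limits. Compound 4 (`O=C(NO)c1cccc(-c2cn([C@@H]3C[C@@H](C(=O)O)N(CCCc4ccccc4)C3)nn2)c1`) differs from compound 3 in that (the two compounds have the same atoms and bonds and differ only in configuration as drawn: 1 of 2 stereo elements differ; a stereocentre at a saturated ring carbon is drawn S in compound 3 and R in compound 4). With every value shown at the limit and no readable step, there is no basis for expecting a change beyond the scatter in this assay. Compound 4 is therefore estimated at 5% (0% to 15%), an expected step that the limit leaves unreadable from compound 3 to compound 4.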

Compound 4, a percentage reported as inhibition, at one concentration (the size of the read-out at that concentration, not a potency): < 10%
Compound 4 ended at the assay's limit (the forecaster's own chance of this, stated with the estimate: 80%); the middle value is on the limit's open side.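

In this assay compound 4 gives < 10%, which is a limit. Its steps from compound 1, compound 2 and compound 3 cannot be read. The compounds shown leave open whether configuration, or carboxy in place of hydroxymethyl, alters inhibition at all.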